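Swapping an Aryl Group on a Shared Core

A few compounds are considered here, and "the series" means these few. Any claim that something is new, unique, unknown or untested is made for them only; others in the source may bear on it.

Of the compounds shown here, three built on one shared core have been tested in a functional assay on U-251 cells (Homo sapiens) for inhibition, read by sulforhodamine B assay, with a stated time of 48 h, tested at 10 uM; a lower number here means less inhibition, a higher number more inhibition at the concentration tested (going by the name of the read-out). Compound 1 `CC(=O)c1ccc(-c2cn3ccnc3c(-c3ccc4ncn(C5CCCCC5)c4c3)n2)cc1` gives 3.02%. Compound 2 `Fc1ccccc1-c1cn2ccnc2c(-c2ccc3ncn(C4CCCCC4)c3c2)n1` gives 11.4%, and compound 3 `Cc1cccc(-c2cn3ccnc3c(-c3ccc4ncn(Cc5ccccc5)c4c3)n2)c1` gives 19.4%. Compound 3 stands highest of the three, though its gap to compound 2 lies within the scatter; only its gap to compound 1 lies beyond it. Compound 4 `c1ccc(Cn2cnc3ccc(-c4nc(-c5cccc6ccccc56)cn5ccnc45)cc32)cc1` has not yet been measured. It differs from compound 3 in one place: naphthalen-1-yl in place of 3-methylphenyl on an aromatic carbon. Going by the values given here, the only measured step that changes the group at this same place is a number 8.4 percentage points higher from compound 1 to compound 2 (within the scatter), a step within the scatter. Therefore the step of a number 0.6 percentage points higher from compound 3 to compound 4 (within the scatter) is expected to stay within the scatter as well. Compound 4 is estimated at 20%, with a range from 5% to 40%.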

Compound 4, a percentage reported as inhibition, at one concentration (the size of the read-out at that concentration, not a potency): 5.53%
For compound 4 the middle estimate is 14.5 percentage points above the measured one, within the range that was stated.
By their numbers in this assay, from the lowest: compounds 1, 4, 2 and 3 (each within the scatter of the next, the first and the last beyond it).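

In this assay, going by these compounds alone, the change to naphthalen-1-yl gives a number 13.9 percentage points lower from compound 3 to compound 4 (beyond the scatter), the first step at this place that lies beyond the scatter, so the group here can affect the read-out. Both groups contain only carbon and have no hydrogen-bond donors or acceptors, yet the entering group has two six-membered aromatic rings where the leaving group has one. No measurement shown gives an explanation for this step. From the compounds shown here alone, it remains open how an amine or a carboxylic acid at this place would read. Going by these compounds, whether naphthalen-1-yl gives a similar step on the core of compound 1 also remains open.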